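Pyridyl for Thienyl on the Sulfonyl of Compound 1

This account rests on a few compounds, and the source may have more. Where it says the series, first, only, none or still open, it means among the compounds named here.

Among the measured compounds shown here, compound 1 `COc1cc(C(=O)NS(=O)(=O)c2cccs2)ccc1Cn1ccc2ccc(NC(=O)CC3CCCC3)cc21` is one of three compounds measured in a functional assay (trachea) for antagonist activity, with Cavia porcellus as the target; on this read-out higher numbers stand for higher potency (the scale is a negative logarithm) and lower numbers for lower potency. In this assay compound 1 gives 9.6, the second highest of the three numbers. Compound 2 `CCCCC(CC)C(=O)Nc1ccc2ccn(Cc3ccc(C(=O)NS(=O)(=O)c4ccccc4)cc3OC)c2c1` gives 8.6 in this assay, a number beyond the scatter below compound 1, while compound 3 `COc1cc(C(=O)NS(=O)(=O)c2ccccc2C)ccc1Cn1ncc2ccc(NC(=O)CC3CCCC3)cc21` gives 10.9, a number beyond the scatter above it. Compound 4 `COc1cc(C(=O)NS(=O)(=O)c2ccccn2)ccc1Cn1ccc2ccc(NC(=O)CC3CCCC3)cc21` differs from compound 1 in one place: pyridin-2-yl in place of thiophen-2-yl on a sulfonyl sulfur. For the measured compounds named here, no measured pair shows this change, so its direction is open. The expected step is a number 0.20 log units lower from compound 1 to compound 4 (within the scatter), none beyond the scatter in either direction. On that basis compound 4 is expected to give 9.4 in this assay, within 8.7 to 10.1.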

Compound 4, negative logarithm of the antagonist equilibrium constant: 8.9
Beside the measured number, compound 4's estimate is 0.50 log units above it, within the range that was stated.
By their numbers in this assay, from the lowest: compounds 2 and 4 (each within the scatter of the next); then compound 1; then compound 3.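

In this assay, among the compounds shown here, pyridin-2-yl in place of thiophen-2-yl on the sulfonyl sulfur gives a number 0.70 log units lower from compound 1 to compound 4 (beyond the scatter) and provides the first one-place step at this position. Though modest, the step shows that this position distinguishes between these two aromatic rings, each with one hetero atom. Nothing available explains the drop.

Open, going by these compounds, is whether pyridin-3-yl or furan-2-yl on this sulfonyl sulfur would give a similar step. Also open, on these data alone, is whether the step would carry over to the core of compound 3.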